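This account rests on a few compounds, and the source may have more. Where it says the series, first, only, none or still open, it means among the compounds named here.

In a physicochemical assay for lipophilicity, measured as octanol-water partition (on this read-out lower numbers stand for lower lipophilicity and higher numbers for higher lipophilicity), the series so far reads:

- compound 1 `C/C(=N\NC(=O)COc1cccc2ccccc12)c1cccc([N+](=O)[O-])c1` gives 3.37
- compound 2 `C/C(=N\NC(=O)COc1cccc2ccccc12)c1ccc(O)cc1O` gives 4.31
- compound 3 `C/C(=N\NC(=O)COc1cccc2ccccc12)c1ccccc1O` gives 3.08

Compound 3 at 3.08 shares the low end of these numbers with compound 1. The measured series shows a number 0.29 log units lower from compound 1 to compound 3 (within the scatter) and also a number 1.23 log units lower from compound 2 to compound 3 (beyond the scatter) as the widest gap.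

The next change is 4-bromophenyl in place of 2-hydroxyphenyl on a carbon with a double bond to nitrogen and gives compound 4 `C/C(=N\NC(=O)COc1cccc2ccccc12)c1ccc(Br)cc1` with 4-bromophenyl in place of 2-hydroxyphenyl on a carbon with a double bond to nitrogen.

Among the measured compounds shown here, no measured compound carries bromine, so no step bears on this change directly. The nearest evidence is the two swaps of the whole group at this same place, which are a number 0.29 log units lower from compound 1 to compound 3 (within the scatter) and a number 0.94 log units higher from compound 1 to compound 2 (beyond the scatter) in the data. Those two steps set the likely size at modest, not large. They do not fix the direction, and an upward move is a judgement resting on the structural change alone.

The expected move is a number 0.82 log units higher from compound 3 to compound 4 (beyond the scatter) as an estimate, clear of the scatter but with wide uncertainty. In this assay the estimate for compound 4 is 3.9 and it is expected to fall between 3.3 and 4.6.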

Compound 4, partition coefficient: 3.61
Compound 4: middle estimate off by 0.29 log units, on the high side, and the stated range covers the measured number.
By their numbers in this assay, from the lowest: compounds 3, 1 and 4 (each within the scatter of the next, the first and the last beyond it); then compound 2.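

In this assay, the step of a number 0.53 log units higher from compound 3 to compound 4 (beyond the scatter) is a whole-group swap at this place that clears the scatter, which the swap between 2-hydroxyphenyl and 3-nitrophenyl did not do; the entering 4-bromophenyl counts no hydrogen-bond donor or acceptor, against one of each for the leaving group. The two hydroxy-bearing compounds now lie on opposite sides of compound 4, with a number 0.70 log units lower from compound 2 to compound 4 (beyond the scatter) on one side and compound 3 on the other, so across these four compounds the presence of a hydroxy group does not alone set the number, while a number 0.24 log units higher from compound 1 to compound 4 (within the scatter) leaves the bromine and nitro compounds unresolved. Nothing available explains these differences through a measured property of the groups.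

With a single bromine compound, the contribution of the bromine cannot be separated from the loss of the hydroxy group, and plain phenyl at this place would give the missing reference. From the compounds shown here alone, it also remains open how 4-chlorophenyl, 4-methoxyphenyl or 4-aminophenyl would sit relative to 4-bromophenyl, and whether moving the bromine elsewhere on the phenyl ring would shift the number.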